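Hydrazone acid series: carboxy replaces methoxy on the aryl ring

The source may report more compounds than this note shows. Statements on the series, on what has been measured and on what is new or still open speak of the compounds shown alone.

Measured so far:
compound 1 `CC1CC/C(=N\Nc2ccccc2O)c2ncc(C(=O)O)c(=O)n21` — 0.26 umol/kg
compound 2 `COc1ccc(N/N=C2\CCC(C)n3c2ncc(C(=O)O)c3=O)cc1` — 0.8 umol/kg

In a functional assay on the whole organism for inhibition, with Rattus norvegicus as the target (on this read-out higher numbers stand for an effect only at larger amounts of compound and lower numbers for an effect already at smaller amounts), compound 1 gives 0.26 umol/kg. Among the compounds with values here, compound 2 gives 0.8 umol/kg, the highest of the two numbers available; the nearest is compound 1, and the step of a 3.1-fold higher number from compound 1 to compound 2 (0.49 log units; beyond the scatter) is the only measured step. The change there is the exchange of the group on the amine nitrogen, not a change on the aryl ring itself.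

Compound 3 `CC1CC/C(=N\Nc2ccc(C(=O)O)cc2)c2ncc(C(=O)O)c(=O)n21` has not yet been run in this assay. Relative to compound 2 the difference is carboxy in place of methoxy on an aromatic carbon. Within the data shown here, no measured step concerns a change of this kind, a substituent exchange on the aromatic carbon of the ring itself, so the step from compound 1 to compound 2 bears on it only loosely, as a measure of how much one aryl change has moved the number.

Given that, the expected step from compound 2 to compound 3 in this assay is a 1.3-fold higher number from compound 2 to compound 3 (0.10 log units; within the scatter), with no firm direction and within or close to the scatter. Compound 3 is thus estimated at 1 umol/kg, in the range 0.3 umol/kg to 3 umol/kg.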

Compound 3, dose for 50% inhibition: 7.6 umol/kg
Estimate against measurement, compound 3: 7.6-fold (0.88 log units) below; measured number above the stated range.
By their numbers in this assay, from the lowest: compound 1; then compound 2; then compound 3.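

In this assay, carboxy in place of methoxy on an aromatic carbon, para to a large group, gives a 9.5-fold higher number from compound 2 to compound 3 (0.98 log units; beyond the scatter) and so shows that the series is sensitive to the group held at this carbon. The earlier step, a 3.1-fold higher number from compound 1 to compound 2 (0.49 log units; beyond the scatter), exchanged one substituted aryl pattern for another and could not isolate a single exchange at this carbon, whereas here the methoxy-to-carboxy exchange is the only difference between the two compounds. Nothing available bears on why the number rises with this exchange.

The compounds shown leave open whether the higher dose is particular to the free carboxy group or would also appear with other groups at this carbon, such as a methyl ester, a primary amide or an amine. As far as these compounds go, it also remains open where a small non-oxygen substituent such as methyl or chlorine would fall relative to methoxy and carboxy, and whether the same exchange would give a step of similar size in another aryl setting.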